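A few compounds are considered here, and "the series" means these few. Any claim that something is new, unique, unknown or untested is made for them only; others in the source may bear on it.

Measured so far:
compound 1 `CC[C@](O)(c1cn(Cc2ccc3c(-c4ccc(F)cc4)c(C(N)=O)sc3c2)nn1)C(F)(F)F` with 55 nM in an assay on isolated protein for inhibition of Polyunsaturated fatty acid 5-lipoxygenase (Homo sapiens); on this read-out lower numbers stand for stronger inhibition and higher numbers for weaker inhibition
compound 2 `CC[C@@](O)(c1cn(Cc2ccc3c(-c4ccc(F)cc4)c(C(N)=O)sc3c2)nn1)C(F)(F)F` with 1160 nM in this assay

Compound 1 gives the lowest of the two numbers; compound 2 sits at a 21-fold higher number from compound 1 to compound 2 (1.32 log units; beyond the scatter), a step that rests on the fact that compounds 1 and 2 differ only in the configuration as drawn alone. The step from compound 1 to compound 3 `CC[C@](O)(c1cn(Cc2ccc3c(-c4ccc(F)cc4)c(C(=O)O)sc3c2)nn1)C(F)(F)F` is of another kind: hydroxy in place of amino on a carbonyl carbon. For the measured compounds named here, no measured step touches this carbonyl substituent, so the change is read without a precedent. For compound 3 a moderate rise is expected, a 3.6-fold higher number from compound 1 to compound 3 (0.56 log units; beyond the scatter), with wide uncertainty. Compound 3 is estimated at 200 nM, ranging from 40 nM to 1500 nM.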

Compound 3, half-maximal inhibitory concentration: > 10000 nM
Compound 3 was reported as a limit; the forecaster's own chance of this, stated with the estimate: 5%; middle value at least 50-fold (1.69 log units) away from the limit.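

In this assay, the carbonyl substituent, untouched by the earlier pair, proves highly sensitive: hydroxy in place of amino on a carbonyl carbon gives an at least 180-fold higher number from compound 1 to compound 3 (2.25 log units; beyond the scatter). Compound 3 is reported only as a limit, > 10000 nM. The step is therefore a minimum, and its full size cannot be read: the limit of > 10000 nM in this assay, at which 1 of the 3 values shown sits.

Open, on these data alone, is whether this loss is specific to the carboxy group or extends to other replacements of the carbamoyl group, such as a methyl ester, a methylamide or a nitrile.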